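Series notes: pyridin-2-yl in place of 3-methoxyphenyl

The source may hold more compounds than are shown below. What is called first, only, known or untested is meant among the compounds shown, and "the series" means these compounds.

Compound 1 `COc1cccc(/C=C/C(=O)c2ccc(OC)c3c2OC(C)(C)C=C3)c1` has been run in a functional assay on K562 cells (Homo sapiens) for antiproliferative activity, read by MTT assay, with a stated time of 24 h; on this read-out lower numbers stand for stronger inhibition and higher numbers for weaker inhibition. In this assay compound 1 returns only a limit, > 10000 nM, and no number. Compound 2 `COc1cc(OC)c(OC)cc1/C=C/C(=O)c1ccc(OC)c2c1OC(C)(C)C=C2` likewise gives the limit > 10000 nM in this assay. Compound 3 `COc1ccc(C(=O)/C=C/c2ccc(N(c3ccccc3)c3ccccc3)cc2)c2c1C=CC(C)(C)O2` also gives the limit > 10000 nM in this assay. For the measured compounds named here, compound 1 therefore stands among values that are all limits, as the limit of > 10000 nM in this assay, at which 3 of the 3 values shown sit, shows, and no measured step exists between any pair. Compound 4 `COc1ccc(C(=O)/C=C/c2ccccn2)c2c1C=CC(C)(C)O2` is the next candidate. It differs from compound 1 by pyridin-2-yl in place of 3-methoxyphenyl on a double-bonded chain carbon bound to a double-bonded chain carbon. Going by the values given here, with every value so far a limit, the change from compound 1 to compound 4 is expected to be none beyond the scatter. Compound 4 is estimated at 15000 nM in this assay, within 5000 nM to 50000 nM. The expected step is a step that the limit leaves unreadable from compound 1 to compound 4, most likely again ending at the limit.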

Compound 4, half-maximal inhibitory concentration: 5400 nM
Compound 4: middle estimate off by 2.8-fold (0.44 log units), on the high side; the measured number falls inside the stated range.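

In this assay, pyridin-2-yl in place of 3-methoxyphenyl on a double-bonded chain carbon bound to a double-bonded chain carbon gives an at least 1.8-fold lower number from compound 1 to compound 4 (0.26 log units; that floor lies within the scatter). Compound 4 is the only compound shown with a number and not a limit, so this place on the shared core can yield a readable value, though the true size of the step stays unfixed. The other values remain at one limit: the limit of > 10000 nM in this assay, at which 3 of the 4 values shown sit.

As far as these compounds go, whether the ring nitrogen or simply the smaller ring matters remains open. Pyridin-4-yl on the same carbon would bear on that question.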